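Swapping the aryl group in a covalent thiazolopyrimidine-type inhibitor

This account rests on a few compounds, and the source may have more. Where it says the series, first, only, none or still open, it means among the compounds named here.

Compound 2 `C=C(Br)C(=O)Nc1cccc(-c2cn3nc(-c4ccc(OC)c(OC)c4)sc3n2)c1` is the (1-bromoethenyl)carbonyl amide of compound 1 `COc1ccc(-c2nn3cc(-c4cccc(N)c4)nc3s2)cc1OC`. In a functional assay on CCRF-CEM cells (Homo sapiens) for inhibition, read by cell counting, with a stated time of 3 days (a higher number here means a weaker inhibitor, a lower number a stronger inhibitor), compound 2 gives 380 nM, the lowest of the two numbers available, while compound 1 gives 14000 nM. Among the compounds with values here, the single measured step, a 37-fold lower number from compound 1 to compound 2 (1.57 log units; beyond the scatter), describes only the addition of that reactive group on the nitrogen. Compound 3 `Nc1cccc(-c2cn3nc(-c4ccc(F)cc4)sc3n2)c1` carries a 4-fluorophenyl where compound 1 carries the 3,4-dimethoxyphenyl. In this assay compound 3 reaches only (the limit of >= 250000 nM in this assay, at which 1 of the 3 values shown sits), so the value of compound 3, >= 250000 nM, is a limit rather than a number.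

Compound 4 `C=C(Br)C(=O)Nc1cccc(-c2cn3nc(Cc4ccc(OC)cc4)sc3n2)c1` keeps the reactive amide of compound 2 but differs elsewhere: 4-methoxybenzyl in place of 3,4-dimethoxyphenyl on an aromatic carbon. Within the data shown here, no measured step follows this kind of replacement, so the only guide is that the free-amine pair, compound 1 and compound 3, moved from a number to a limit when the 3,4-dimethoxyphenyl was exchanged. On that slim basis a loss of potency is expected, though its size is uncertain. The expected step of a 3.9-fold higher number from compound 2 to compound 4 (0.60 log units; beyond the scatter) is estimated as a moderate weakening. Compound 4 is therefore estimated at 1500 nM in this assay, with a plausible range from 300 nM to 10000 nM.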

Compound 4, half-maximal inhibitory concentration: 2300 nM
Estimate against measurement, compound 4: 1.5-fold (0.19 log units) below; measured number inside the range.
By their numbers in this assay, from the lowest: compound 2; then compound 4; then compound 1. At a limit, above all of these: compound 3.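

With the reactive amide held fixed, this assay records a 6.1-fold higher number from compound 2 to compound 4 (0.78 log units; beyond the scatter), which shows directly that this position on the five-membered aromatic ring affects the number even when the reactive group is present. The exchange of 3,4-dimethoxyphenyl for 4-methoxybenzyl weakens inhibition without abolishing it, as compound 4 still gives 2300 nM, a measured number and not a limit. This single step changes both the methylene link to the ring and the pattern of methoxy groups, so it cannot separate the two, and nothing in the data gives a reason for the weakening.

The compounds shown leave open whether the link or the methoxy pattern matters more, a question that a pair such as 4-methoxyphenyl and 3,4-dimethoxybenzyl on the same reactive amide would address. They also leave open how far this position tolerates quite different groups, such as a morpholine or a carboxylic acid on the phenyl ring, or a longer chain in place of the methylene link.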